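Phenyl ring substituent swap: methoxy to cyano, compound 4

A few compounds are considered here, and "the series" means these few. Any claim that something is new, unique, unknown or untested is made for them only; others in the source may bear on it.

Compound 1 `Nc1nc(-c2ccccc2)nc2sc(-c3ccccc3)nc12` carries an unsubstituted phenyl ring on the shared core, and in an assay on CHO cells for displacement of a labelled ligand from adenosine receptor A1 (Homo sapiens), read by scintillation counting, with a stated time of 3 h (a higher number here means a weaker inhibitor, a lower number a stronger inhibitor), compound 1 gives 148 nM. Compound 2 `COc1ccc(-c2nc(N)c3nc(-c4ccccc4)sc3n2)cc1` adds a methoxy group to that ring, and in this assay compound 2 gives 225 nM. Compound 3 `COc1cccc(-c2nc(N)c3nc(-c4ccccc4)sc3n2)c1` carries the methoxy group at a different carbon of the same ring, and in this assay compound 3 gives 176 nM. The steps of a 1.5-fold higher number from compound 1 to compound 2 (0.18 log units; within the scatter) and a 1.2-fold higher number from compound 1 to compound 3 (0.08 log units; within the scatter) both remain within the scatter, as does a 1.3-fold lower number from compound 2 to compound 3 (0.11 log units; within the scatter). Compound 3 therefore holds the second highest of the three numbers, with all three lying within the scatter of one another, so no order among them can be claimed.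

Compound 4 `N#Cc1cccc(-c2nc(N)c3nc(-c4ccccc4)sc3n2)c1` differs from compound 3 by cyano in place of methoxy on an aromatic carbon. Among the measured compounds shown here, no measured step exchanges one group for another at this carbon; the steps that bear on it show only that a methoxy group, at either carbon tried, left the number close to that of compound 1. For the measured compounds named here, the cyano group has no precedent. For compound 4 the expected step is a 1.1-fold higher number from compound 3 to compound 4 (0.06 log units; within the scatter), that is, none beyond the scatter, with the range widened for the untried group. For compound 4 the estimate in this assay is 200 nM, between 70 nM and 600 nM.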

Compound 4, inhibition constant: 594 nM
For compound 4 the middle estimate is 3.0-fold (0.47 log units) below the measured one, within the range that was stated.
By their numbers in this assay, from the lowest: compounds 1, 3 and 2 (each within the scatter of the next); then compound 4.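

In this assay, among the compounds shown here, this carbon proves not to be indifferent to its substituent, since replacing the methoxy group with cyano gives the first change beyond the scatter (a 3.4-fold higher number from compound 3 to compound 4 (0.53 log units; beyond the scatter)), and the same holds for cyano in place of hydrogen (a 4.0-fold higher number from compound 1 to compound 4 (0.60 log units; beyond the scatter)). The comparison with the other methoxy compound, 3-cyanophenyl in place of 4-methoxyphenyl, points the same way (a 2.6-fold higher number from compound 2 to compound 4 (0.42 log units; beyond the scatter)), so compound 4 stands as the weakest of the four, apart from the three earlier compounds, which remain within the scatter of one another, although all three new steps are only modest. Nothing available here accounts for the difference between the cyano and methoxy groups at this carbon.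

On these data alone, whether an amine, a hydroxyl group or a carboxylic acid at this carbon would stay with compound 3 or move with compound 4 remains open. Cyano also appears at only one carbon of this ring, so the compounds shown do not tell whether the step is particular to this place or would recur at the carbon carrying the methoxy group in compound 2.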